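A few compounds are considered here, and "the series" means these few. Any claim that something is new, unique, unknown or untested is made for them only; others in the source may bear on it.

Measured compounds in an ADME assay on MT4 cells (Homo sapiens) for cytotoxicity, read by MTT assay; on this read-out lower numbers stand for higher toxicity in this test and higher numbers for lower toxicity in this test:
- compound 1, `O=C1c2ccccc2C(=O)N1CCOC(=S)N(C(=O)c1ccccc1[N+](=O)[O-])c1ccc(Cl)cc1`: 21000 nM
- compound 2, `Cc1ccc(C(=O)N(C(=S)OCCN2C(=O)c3ccccc3C2=O)c2ccc(Cl)cc2)cc1`: reported only as a limit, > 100000 nM
- compound 3, `O=C1c2ccccc2C(=O)N1CCOC(=S)N(C(=O)c1ccc(Cl)c(Cl)c1)c1ccc(Cl)cc1`: 35000 nM

Compound 3 holds the higher of the two numbers read, with compound 1 nearest at a 1.7-fold higher number from compound 1 to compound 3 (0.22 log units; within the scatter). Compound 2 sits at the limit of > 100000 nM in this assay, at which 1 of the 3 values shown sits, so no number is known for it. The step of an at least 2.8-fold lower number from compound 2 to compound 3 (0.45 log units; beyond the scatter) is the only one beyond the scatter that ends at compound 3.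

Compound 4, `O=C1c2ccccc2C(=O)N1CCOC(=S)N(C(=O)c1ccc2ccccc2c1)c1ccc(Cl)cc1`, differs from compound 3 by naphthalen-2-yl in place of 3,4-dichlorophenyl on a carbonyl carbon. Both steps that bear on this position, a 1.7-fold higher number from compound 1 to compound 3 (0.22 log units; within the scatter) and an at least 2.8-fold lower number from compound 2 to compound 3 (0.45 log units; beyond the scatter), are modest in size, so an exchange of the aryl on the carbonyl carbon is expected to move this assay only modestly, direction uncertain, possibly not beyond the scatter. Compound 4 is therefore estimated at 30000 nM, between 10000 nM and 100000 nM, a step of a 1.2-fold lower number from compound 3 to compound 4 (0.07 log units; within the scatter).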

Compound 4, half-maximal cytotoxic concentration: 37000 nM
Compound 4: the middle estimate sits 1.2-fold (0.09 log units) below what was measured, and the stated range covers the measured number.
By their numbers in this assay, from the lowest: compounds 1, 3 and 4 (each within the scatter of the next). At a limit, above all of these: compound 2.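

In this assay, naphthalen-2-yl on the carbonyl carbon brings 2 six-membered aromatic rings of carbon only, yet it reads level with 3,4-dichlorophenyl, a 1.1-fold higher number from compound 3 to compound 4 (0.02 log units; within the scatter), and with 2-nitrophenyl, a 1.8-fold higher number from compound 1 to compound 4 (0.25 log units; within the scatter). Among the aryl groups shown, only 4-methylphenyl stands apart: an at least 2.7-fold lower number from compound 2 to compound 4 (0.43 log units; beyond the scatter). Compound 2 is a limit, not a number: the limit of > 100000 nM in this assay, at which 1 of the 4 values shown sits.

From the compounds shown here alone, it remains open whether an aryl group carrying an amine or a carboxylic acid on this carbonyl carbon would read level with compound 4. Going by these compounds, the true distance of compound 2 from the others also remains open.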